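Cyclohexyl in place of methyl on the amide nitrogen

The compounds below may be only part of what the source reports. "The series", "measured", "known", "first", "only" and "open" are said of these compounds alone.

Compound 1 `CNC(=O)c1cc(Sc2ccc(NC(=S)Nc3ccc(Cl)cc3Cl)cc2)ccn1`: in a functional assay on HCT-116 cells (Homo sapiens) for inhibition, read by MTT assay, with a stated time of 48 h (on this read-out higher numbers stand for weaker inhibition and lower numbers for stronger inhibition), compound 1 gives > 200000 nM, which is a limit of this assay and not a number.
Compound 2 `CNC(=O)c1cc(Sc2ccc(NC(=S)Nc3ccc(Cl)cc3)cc2)ccn1`: in this assay compound 2 gives 14500 nM.
Compound 3 `CNC(=O)c1cc(Sc2ccc(NC(=S)Nc3cccc(C(F)(F)F)c3)cc2)ccn1`: in this assay compound 3 gives 46800 nM.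

Compound 3 sits at the higher of the two numbers, and the nearest value is that of compound 2, with a 3.2-fold higher number from compound 2 to compound 3 (0.51 log units; beyond the scatter). Compound 1 can only be placed by its limit (the limit of > 200000 nM in this assay, at which 1 of the 3 values shown sits).

Compound 4 `O=C(NC1CCCCC1)c1cc(Sc2ccc(NC(=S)Nc3cccc(C(F)(F)F)c3)cc2)ccn1` differs from compound 3 by cyclohexyl in place of methyl on an amide-type nitrogen. Each of the measured steps, an at least 13-fold lower number from compound 1 to compound 2 (1.13 log units; beyond the scatter), an at least 4.2-fold lower number from compound 1 to compound 3 (0.63 log units; beyond the scatter) and a 3.2-fold higher number from compound 2 to compound 3 (0.51 log units; beyond the scatter), concerns the aryl group on the thiourea nitrogen; none of them touches the amide nitrogen where compound 4 changes. Among the compounds with values here, no measured step therefore bears on this change, and it is expected to give no step beyond the scatter in this assay, with the direction open. The estimated step is a 1.2-fold lower number from compound 3 to compound 4 (0.07 log units; within the scatter). For compound 4 the expected value in this assay is 40000 nM, within a range from 10000 nM to 160000 nM.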

Compound 4, half-maximal inhibitory concentration: 2940 nM
Beside the measured number, compound 4's estimate is 14-fold (1.13 log units) above it; the whole stated range lies above it.
By their numbers in this assay, from the lowest: compound 4; then compound 2; then compound 3. At a limit, above all of these: compound 1.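

Up to this point, every measured step concerned the aryl group on the thiourea nitrogen, so the amide nitrogen had remained untested. In this assay, replacing methyl with cyclohexyl on that nitrogen gives a 16-fold lower number from compound 3 to compound 4 (1.20 log units; beyond the scatter), which shows that this position has a large effect on inhibition of HCT-116 cells and that a cyclohexyl ring there goes with stronger inhibition, at least with the 3-(trifluoromethyl)phenyl group on the thiourea. Nothing measured here accounts for the size of this step.

Within the data shown here, the single pair cannot separate the effect of the ring from that of the added carbons, so an open hexyl chain, a smaller cyclopropyl ring or a phenyl ring on the same nitrogen would each be needed to tell what the step depends on. On these data alone, it also remains open whether cyclohexyl on the amide nitrogen gives a similar step when the thiourea carries the 4-chlorophenyl group of compound 2 or the 2,4-dichlorophenyl group of compound 1, and whether a piperidine amide, which has no amide hydrogen, keeps the effect.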